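Swapping Ethylamino for Benzylsulfanyl on a Shared Core

A few compounds are considered here, and "the series" means these few. Any claim that something is new, unique, unknown or untested is made for them only; others in the source may bear on it.

Measured compounds:
- Compound 1 `[O-][n+]1ccc2c(c1)ncn2[C@H]1C[C@H](O)[C@@H](CO)O1`: < 5%
- Compound 2 `CCNc1nccc2c1ncn2C1O[C@H](CO)[C@@H](O)[C@H]1O`: 8%

Of the compounds shown here, two have been measured in a functional assay on EL4 cells (Mus musculus) for inhibition, tested at 100 uM; a higher number here means more inhibition at the concentration tested (going by the name of the read-out), a lower number less inhibition. Compound 1 gives < 5% in this assay, and this is a limit of the assay rather than a number. Compound 2 gives 8% in this assay, the only number among the measurements shown. The result of compound 1 sits at the limit (the limit of < 5% in this assay, at which 1 of the 2 values shown sits). Going by the values given here, no step between measured compounds that differ in one place is available, so there is no measured comparison on which to build.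

Compound 3 `OC[C@H]1OC(n2cnc3c(SCc4ccccc4)nccc32)[C@H](O)[C@@H]1O` is not yet measured. It differs from compound 2 as follows: benzylsulfanyl in place of ethylamino on an aromatic carbon. The ethylamino group gives way to a benzylsulfanyl group on the same aromatic carbon.

With both measured values low, compound 3 is expected to stay low as well. The step from compound 2 to compound 3 in this assay is estimated to be a number 4 percentage points higher from compound 2 to compound 3 (within the scatter), not clearly beyond the scatter. Compound 3 is therefore estimated at 12%, within a range from 0% to 35%.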

Compound 3, a percentage reported as inhibition, at one concentration (the size of the read-out at that concentration, not a potency): 30%
Beside the measured number, compound 3's estimate is 18 percentage points below it; the measured number falls inside the stated range.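

In this assay, going by these compounds alone, the group on this aromatic carbon of the shared core clearly matters: benzylsulfanyl in place of ethylamino gives a number 22 percentage points higher from compound 2 to compound 3 (beyond the scatter), the first measured step in the set. The swap changes several things at once, since a sulfur takes over from the nitrogen that links the group to the core, a six-membered aromatic ring of carbon only enters, and the hydrogen-bond donor leaves, so this single step cannot show which of these changes matters. Compound 1 differs from these compounds in more than one place, so it adds no step, and its result is a limit of the assay and not a number: the limit of < 5% in this assay, at which 1 of the 3 values shown sits.

The compounds shown leave open whether the gain follows the sulfur or the aromatic ring: a benzylamino group would keep the ring on a nitrogen link, while a methylsulfanyl group would keep the sulfur without the ring. Also open, as far as these compounds go, is how potent compound 3 is, as 30% is the size of the read-out at one concentration and not a potency.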